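Varying the benzothiazole end of a pyrazolopyrimidine amide

This account rests on a few compounds, and the source may have more. Where it says the series, first, only, none or still open, it means among the compounds named here.

Compound 1 `O=C(Nc1nc2ccc(F)cc2s1)c1cc(-c2ccc(F)cc2)n2nc(-c3ccccc3)cc2n1`: 14800 nM
Compound 2 `COc1ccc(-c2cc(C(=O)Nc3nc4ccc(F)cc4s3)nc3cc(-c4ccccc4)nn23)cc1`: 11700 nM
Compound 3 `COc1cc(-c2cc(C(=O)Nc3nc4ccc(F)cc4s3)nc3cc(-c4ccccc4)nn23)cc(OC)c1OC`: 22400 nM

Three amides sharing one core have been tested in a functional assay on A549 cells (Homo sapiens) for cytotoxicity, read by MTT assay, with a stated time of 48 h; a lower number here means a stronger inhibitor, a higher number a weaker inhibitor. Compound 1 gives 14800 nM; its number sits between those of compound 2 and compound 3, but neither neighbour is separated from it by more than the scatter: a 1.3-fold lower number from compound 1 to compound 2 (0.10 log units; within the scatter) and a 1.5-fold higher number from compound 1 to compound 3 (0.18 log units; within the scatter). The remaining pair likewise stays within the scatter, a 1.9-fold higher number from compound 2 to compound 3 (0.28 log units; within the scatter). Compound 4 `Cc1cc2nc(NC(=O)c3cc(-c4ccc(F)cc4)n4nc(-c5ccccc5)cc4n3)sc2cc1C` has not yet been measured in this assay.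

Compound 4 differs from compound 1 at the amide-type nitrogen: 5,6-dimethyl-1,3-benzothiazol-2-yl in place of 6-fluoro-1,3-benzothiazol-2-yl on an amide-type nitrogen. None of the three measured steps touches this part of the molecule; all of them alter the aryl group at the other end of the core, and all of them stayed within the scatter. Going by the values given here, no step in the set therefore bears directly on the change from compound 1 to compound 4, and the only guidance is that every variation tried so far has left this assay essentially unmoved.

On that basis compound 4 is expected to give about 15000 nM, somewhere between 6000 nM and 40000 nM. Among the compounds with values here, the estimated step, a 1.0-fold higher number from compound 1 to compound 4 (0.01 log units; within the scatter), is expected to lie within the scatter, with the range kept wide since no measured step bears on this position.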

Compound 4, half-maximal inhibitory concentration: 12600 nM
The estimate for compound 4 lay 1.2-fold (0.08 log units) above the measured number, within the range that was stated.
By their numbers in this assay, from the lowest: compounds 2, 4, 1 and 3 (each within the scatter of the next).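

In this assay, going by these compounds alone, the exchange at the amide-type nitrogen gives a 1.2-fold lower number from compound 1 to compound 4 (0.07 log units; within the scatter), which is the first reading at this end of the molecule, since every earlier step altered the aryl group at the other end of the core. The two groups have the same pair of aromatic rings and the same hydrogen-bond donor and acceptor counts, so this step tests only the substituents on the benzothiazole, and replacing the fluoro pattern with the dimethyl pattern leaves the number within the scatter, as the three aryl steps did. No measurement at hand accounts for this flat result.

The compounds shown leave open whether anything at this end can move the number in this assay beyond the scatter, for instance a carboxylic acid or a primary amine on the benzothiazole in place of the fluoro, or a plain phenyl in place of the whole 5,6-dimethyl-1,3-benzothiazol-2-yl group. On these data alone, it also remains open whether that group would read the same when combined with the 4-methoxyphenyl of compound 2 or the 3,4,5-trimethoxyphenyl of compound 3.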